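Aryl variation on a fused bicyclic alpha-1D agonist series

The source may hold more compounds than are shown below. What is called first, only, known or untested is meant among the compounds shown, and "the series" means these compounds.

Measured compounds:
compound 1 `c1cc(-c2ccn[nH]2)c2c(c1)C(c1ncc[nH]1)CC2` gives 57%
compound 2 `c1cc(-c2ncco2)c2c(c1)C(c1ncc[nH]1)CC2` gives 38%
compound 3 `c1ccc2c(c1)CCCC2c1ncc[nH]1` gives 74%

In a functional assay on CHO cells for agonist activity at Alpha-1D adrenergic receptor (Homo sapiens), read by FLIPR and calcium flux (on this read-out lower numbers stand for smaller maximal responses and higher numbers for larger maximal responses), compound 2 stands lowest of the three numbers. Compound 1 is nearest, with a maximal response higher by a margin beyond the scatter, and compound 3, which carries no group at that place, is furthest, also beyond the scatter. Going by the values given here, the one measured step that touches this position is a number 19 percentage points lower from compound 1 to compound 2 (beyond the scatter), a modest loss on moving from a pyrazole to an oxazole.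

Compound 4 `c1cc(-c2cn[nH]c2)c2c(c1)C(c1ncc[nH]1)CC2` differs from compound 2 as follows: 1H-pyrazol-4-yl in place of 1,3-oxazol-2-yl on an aromatic carbon. Among the compounds with values here, this step returns a pyrazole to the same aromatic carbon, though attached through a different ring carbon than in compound 1, so the step from compound 1 to compound 2 is the only direct guide and its size is expected roughly to recur in the opposite direction. The expected change is a number 17 percentage points higher from compound 2 to compound 4 (beyond the scatter), an increase beyond the scatter, with the range widened for the different attachment point. Compound 4 is therefore estimated at 55%, expected between 38% and 72%.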

Compound 4, largest response reached (Emax), in percent of the reference or control that the assay uses: 52%
Estimate against measurement, compound 4: 3 percentage points above; the range from low to high includes it.
By their numbers in this assay, from the lowest: compound 2; then compounds 4 and 1 (each within the scatter of the next); then compound 3.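

In this assay the move away from 1,3-oxazol-2-yl gives a number 14 percentage points higher from compound 2 to compound 4 (beyond the scatter), so a pyrazole attached through a different ring carbon also stands apart from the oxazole at this place, on an aromatic carbon of the shared core. Changing the attachment of the pyrazole itself gives a number 5 percentage points lower from compound 1 to compound 4 (within the scatter), so 1H-pyrazol-5-yl and 1H-pyrazol-4-yl are not told apart here, and among these three compounds both pyrazoles stand clear of the oxazole, with no compound going against this. The oxazole and the 1H-pyrazol-4-yl group have the same count of heavy atoms and differ in hydrogen-bond donors and acceptors, but no measurement at hand connects that difference with the maximal response.

Still open, from the compounds shown here alone, is how a 1-methylpyrazol-4-yl group, which keeps the pyrazole ring but has a methyl on the ring nitrogen, would read against the two pyrazoles and the oxazole. Also open, going by these compounds, is whether a phenyl or a 1,3-thiazol-2-yl group at the same aromatic carbon would fall with the oxazole or with the pyrazoles.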